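A few compounds are considered here, and "the series" means these few. Any claim that something is new, unique, unknown or untested is made for them only; others in the source may bear on it.

Compound 1 `Cc1cnc(Nc2ccc(CN3CCN(C)CC3)cc2)nc1-c1ccc(F)cc1S(=O)(=O)N1CCCC1` is one of four related molecules in a set that was tested in a functional assay on PSN1 cells (Homo sapiens) for cytotoxicity, read by luminescence, with a stated time of 96 h; a lower number here means a stronger inhibitor, a higher number a weaker inhibitor. For compound 1 the outcome in this assay is "not determined" (no result reported), so no number is available for it. The same holds for compound 2 `CN1CCN(Cc2ccc(Nc3ncc(Cl)c(Nc4ccc(F)cc4S(=O)(=O)N4CCOCC4)n3)cc2)CC1`, which in this assay also stands at "not determined" (no result reported). Among the compounds with values here, the only number in the set belongs to compound 3 `CN1CCN(Cc2ccc(Nc3ncc(Cl)c(Nc4ccc(F)cc4S(=O)(=O)N4CCCC4)n3)cc2)CC1`, which in this assay gives 9 nM, a strongly inhibiting result.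

The step of interest leads from compound 1 to compound 4 `CN1CCN(Cc2ccc(Nc3ncc(Cl)c(-c4ccc(F)cc4S(=O)(=O)N4CCCC4)n3)cc2)CC1`, which has not yet been measured. The change between the two is small: chloro in place of methyl on an aromatic carbon. Nothing else in the molecule is touched.

Since compound 1 carries no number, the size of this step cannot be read from a pair of measured values. Within the data shown here, what can be said is that the only measured compound, compound 3, reaches 9 nM, and that compound 4 shares its chloro group and most of its other parts. On that basis a step from compound 1 to compound 4 in this assay is expected to be no larger than the usual scatter, in either direction. Compound 4 is therefore expected to give about 30 nM in this assay, with a plausible range from 5 nM to 200 nM.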

Compound 4, half-maximal inhibitory concentration: 192 nM
The estimate for compound 4 lay 6.4-fold (0.81 log units) below the measured number; the measured number falls inside the stated range.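

In this assay, within the data shown here, compound 1 stands at "not determined" (no result reported) and so no step from it to compound 4 can be read. The compounds shown leave open whether chloro in place of methyl changes the result in this assay at all, and in which direction. No measured evidence bears on the value of compound 4.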